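The source may report more compounds than this note shows. Statements on the series, on what has been measured and on what is new or still open speak of the compounds shown alone.

Two close relatives set the scene. Compound 1 `CC1CCN(c2nc(C(F)(F)F)ccc2CNC(=O)Nc2ccc3ccncc3c2)CC1` gives 8.4 nM in an assay on isolated protein for antagonist activity at transient receptor potential cation channel subfamily V member 1 (Homo sapiens), read by FLIPR; on this read-out higher numbers stand for weaker inhibition and lower numbers for stronger inhibition. Compound 2 `CC1CCN(c2nc(C(F)(F)F)ccc2CNC(=O)Nc2cnc3ccccc3c2)CC1` gives 9.5 nM in this assay, and on these two numbers compound 2 stands highest, with compound 1 nearest; the step of a 1.1-fold higher number from compound 1 to compound 2 (0.05 log units; within the scatter) swaps one two-ring group for another on the amide-type nitrogen without moving the number beyond the scatter. Compound 3 `CC1CCN(c2nc(C(F)(F)F)ccc2CNC(=O)Nc2ccc3cnncc3c2)CC1` has not yet been measured in this assay. It differs from compound 2 in that (a group of 10 heavy atoms (8 carbon, 2 nitrogen; one six-membered aromatic ring of carbon only, one six-membered aromatic ring with 2 hetero atoms) in place of a group of 10 heavy atoms (9 carbon, 1 nitrogen; one six-membered aromatic ring of carbon only, one six-membered aromatic ring with 1 hetero atom), on an amide-type nitrogen). Among the measured compounds shown here, the only measured step that bears on this, a 1.1-fold higher number from compound 1 to compound 2 (0.05 log units; within the scatter), likewise exchanged one two-ring group for another at the same amide-type nitrogen and stayed within the scatter. A similarly small step is therefore expected here, perhaps nudging the number a little higher, a 1.6-fold higher number from compound 2 to compound 3 (0.20 log units; within the scatter). For compound 3 the expected value in this assay is 15 nM, with a range from 5 nM to 50 nM.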

Compound 3, inhibition constant: 8.9 nM
Compound 3: middle estimate off by 1.7-fold (0.23 log units), on the high side, and the stated range covers the measured number.
By their numbers in this assay, from the lowest: compounds 1, 3 and 2 (each within the scatter of the next).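

A second ring nitrogen at this place, on an amide-type nitrogen, gives a 1.1-fold lower number from compound 2 to compound 3 (0.03 log units; within the scatter) and a 1.1-fold higher number from compound 1 to compound 3 (0.03 log units; within the scatter) in this assay, so both steps stay within the scatter. The group that enters holds 2 hydrogen-bond acceptors where quinolin-3-yl holds 1, and that difference in count leaves no readable mark on this read-out, so the three two-ring groups shown cannot be told apart by their numbers. Nothing measured here bears on why these groups read alike.

From the compounds shown here alone, all three compounds carry a two-ring group with nitrogen in one ring, so it remains open whether naphthalen-2-yl, with carbon only in both rings, or a single phenyl ring would fall in the same range. The rest of the shared core is the same throughout, so these compounds say nothing about changes made elsewhere.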